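Same Ring Swap, Second Core: What to Expect

A few compounds are considered here, and "the series" means these few. Any claim that something is new, unique, unknown or untested is made for them only; others in the source may bear on it.

Going by these compounds, three curcumin-like compounds have been tested, and a fourth is still open. Compound 1, `COc1cccc(/C=C/C(=O)C(=Cc2ccc(O)c(F)c2)C(=O)/C=C/c2cccc(OC)c2OC)c1OC`, was run in a functional assay on HepG2 cells (Homo sapiens) for antiproliferative activity, read by sulforhodamine B assay, with a stated time of 48 h (a higher number here means a weaker inhibitor, a lower number a stronger inhibitor), where compound 1 gives 220 nM. Compound 2, `COc1cc(C=C(C(=O)/C=C/c2cccc(OC)c2OC)C(=O)/C=C/c2cccc(OC)c2OC)cc(Br)c1O`, differs from compound 1 in one place: 3-bromo-4-hydroxy-5-methoxyphenyl in place of 3-fluoro-4-hydroxyphenyl on a double-bonded chain carbon bound to a double-bonded chain carbon In this assay compound 2 gives 240 nM, a step of a 1.1-fold higher number from compound 1 to compound 2 (0.04 log units; within the scatter), so this ring swap left the activity essentially unchanged.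

Compound 3, `COc1ccc(/C=C/C(=O)C(=Cc2ccc(O)c(F)c2)C(=O)/C=C/c2ccc(OC)cc2OC)c(OC)c1`, is built from the same atoms as compound 1, but they are joined differently; the difference between the two cores is not broken down here. In this assay compound 3 gives 1760 nM, the highest number of the three measured compounds, well beyond the scatter from both compound 1 and compound 2.

Compound 4, `COc1ccc(/C=C/C(=O)C(=Cc2cc(Br)c(O)c(OC)c2)C(=O)/C=C/c2ccc(OC)cc2OC)c(OC)c1`, has not been measured. It stands to compound 3 as compound 2 stands to compound 1: 3-bromo-4-hydroxy-5-methoxyphenyl in place of 3-fluoro-4-hydroxyphenyl on a double-bonded chain carbon bound to a double-bonded chain carbon The place of the change is described in the same words for both pairs, so this is the same change carried onto the core of compound 3.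

The expectation rests on one observation only, the step of a 1.1-fold higher number from compound 1 to compound 2 (0.04 log units; within the scatter), which stayed within the scatter. On these data alone, whether the core of compound 3 responds in the same way is untested. Compound 4 is therefore expected to sit close to compound 3, with an estimated step of a 1.1-fold higher number from compound 3 to compound 4 (0.03 log units; within the scatter). Compound 4 is expected to give about 1900 nM in this assay, with a plausible range from 900 nM to 4200 nM.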

Compound 4, half-maximal inhibitory concentration: 1190 nM
Beside the measured number, compound 4's estimate is 1.6-fold (0.20 log units) above it, within the range that was stated.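

Placing 3-bromo-4-hydroxy-5-methoxyphenyl in place of 3-fluoro-4-hydroxyphenyl on the core of compound 3 gives, in this assay, a 1.5-fold lower number from compound 3 to compound 4 (0.17 log units; within the scatter), so on this core too the swap produces no step beyond the scatter. Set beside the earlier result, the two steps cannot be told apart: the same change on two cores in this assay, a 1.1-fold higher number (0.04 log units; within the scatter) from compound 1 to compound 2 and a 1.5-fold lower number (0.17 log units; within the scatter) from compound 3 to compound 4, 1.6-fold (0.21 log units) apart, within the scatter of two such steps. Within the data shown here, this shows that, across these two pairs, the swap carried from one core to the other with the same outcome, but it rests on only two cores and does not show that a third core would respond alike, nor does it explain why the swap makes so little difference in either case.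

The compounds shown leave open what happens when this ring carries a quite different group, such as an amine or a carboxylic acid, in place of the bromine or the fluorine, since every ring compared here keeps its hydroxy group and a halogen. They also leave open whether the agreement seen in this assay would hold in other cell lines, because only this one read-out is available for these four compounds.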